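Thiophen-3-yl replaces 1,3-thiazol-5-yl on a carbonyl carbon

A few compounds are considered here, and "the series" means these few. Any claim that something is new, unique, unknown or untested is made for them only; others in the source may bear on it.

Compound 3 `CCCCCCCCCCCC[C@@H](O)[C@H]1CC[C@H]([C@H](O)CCCCCCCCCCNC(=O)c2cncs2)O1` gives 100000 nM in a functional assay on NCI-H226 cells (Homo sapiens) for inhibition, read by colorimetric assay and sulforhodamine B assay, with a stated time of 48 h; a higher number here means a weaker inhibitor of growth, a lower number a stronger inhibitor of growth. Compound 2 `CCCCCCCCCCCC[C@@H](O)[C@H]1CC[C@H]([C@H](O)CCCCCCCCCCNC(=O)c2ccoc2)O1` stands level with it at 100000 nM, and compound 1 `CCCCCCCCCCCC[C@@H](O)[C@H]1CC[C@H]([C@H](O)CCCCCCCCCCNC(=O)c2cccs2)O1` gives the lowest number, 2090 nM. Compound 4 `CCCCCCCCCCCC[C@@H](O)[C@H]1CC[C@H]([C@H](O)CCCCCCCCCCNC(=O)c2ccsc2)O1` carries thiophen-3-yl in place of 1,3-thiazol-5-yl on a carbonyl carbon. Among the compounds with values here, two measured steps bear on this change, both large: a 48-fold higher number from compound 1 to compound 3 (1.68 log units; beyond the scatter) and a 48-fold higher number from compound 1 to compound 2 (1.68 log units; beyond the scatter). Within the data shown here, only compound 1 holds thiophen-2-yl, and no measurement yet compares that group with thiophen-3-yl, so the expectation is uncertain. A sizeable drop towards compound 1 seems likely, and the expected change is a 17-fold lower number from compound 3 to compound 4 (1.22 log units; beyond the scatter). Compound 4 is estimated at 6000 nM, with an expected range from 1500 nM to 60000 nM.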

Compound 4, concentration for 50% growth inhibition: 2400 nM
Compound 4: middle estimate off by 2.5-fold (0.40 log units), on the high side; the range from low to high includes it.
By their numbers in this assay, from the lowest: compounds 1 and 4 (each within the scatter of the next); then compounds 2 and 3 (each within the scatter of the next).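

In this assay the swap to thiophen-3-yl separates compound 4 sharply from the two inactive-looking rings (a 42-fold lower number from compound 3 to compound 4 (1.62 log units; beyond the scatter) and a 42-fold lower number from compound 2 to compound 4 (1.62 log units; beyond the scatter)). Against thiophen-2-yl the picture differs (a 1.1-fold higher number from compound 1 to compound 4 (0.06 log units; within the scatter)), so the two thiophene attachments cannot be told apart at this position. Among these four compounds, the two thiophene amides sit together at the low numbers, and the furan-3-yl and 1,3-thiazol-5-yl amides sit together at the high numbers. On these data alone, whether a phenyl or furan-2-yl ring on the same carbonyl carbon would join the thiophenes remains open. Nothing measured here explains why the thiophene rings part from the other two.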